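Dimethylamino for Benzylsulfanyl: an Expected Dose

The source may report more compounds than this note shows. Statements on the series, on what has been measured and on what is new or still open speak of the compounds shown alone.

Measured so far:
- compound 1, `OC[C@H]1OC(n2cnc3c(NCc4ccccc4)nccc32)[C@H](O)[C@@H]1O`, in a functional assay on the whole organism (Pleural cavity) with Rattus norvegicus as the target (a higher number here means that more compound is needed for the effect, a lower number that less compound is needed), a limit of the assay, > 9 mg/kg
- compound 2, `OC[C@H]1OC(n2cnc3c(SCc4ccccc4)nccc32)[C@H](O)[C@@H]1O`, in this assay 9 mg/kg

Going by the values given here, compound 2 holds the only number recorded in this assay; the other value shown is a limit rather than a number. Among the compounds with values here, the one measured step, a number no higher from compound 1 to compound 2 (the limit leaves the size open), is not readable in size, since it runs from a limit, as the limit of > 9 mg/kg in this assay, at which 1 of the 2 values shown sits, shows.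

Compound 3, `CN(C)c1nccc2c1ncn2C1O[C@H](CO)[C@@H](O)[C@H]1O`, differs from compound 2 by dimethylamino in place of benzylsulfanyl on an aromatic carbon. The measured step between compound 1 and compound 2 changed the atom joining a benzyl group to the aromatic carbon and kept the benzyl; the step to compound 3 removes the benzyl altogether and brings in a dimethylamino at the same place. Within the data shown here, no measured step bears on that kind of change, so no direction can be drawn from the data in this assay, and a step within the scatter is taken as the neutral expectation.

Compound 3 is therefore estimated at 9 mg/kg in this assay, with a range from 3 mg/kg to 27 mg/kg. That estimate means an expected step of no change at the digits printed from compound 2 to compound 3 (within the scatter).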

Compound 3, dose for half-maximal effect: > 9 mg/kg
Compound 3: no number, only a limit; the forecaster's own chance of this, stated with the estimate: 50%; the middle value lies on the limit itself.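

In this assay, replacing benzylsulfanyl with dimethylamino on the aromatic carbon next to the ring nitrogen gives a number no lower from compound 2 to compound 3 (the limit leaves the size open). Going by these compounds alone, this shows that a change at this position that removes the benzyl group altogether also leaves no number, so compound 2 remains the only compound with a recorded dose, and the benzylamino of compound 1 and the dimethylamino of compound 3 both end in a limit: the limit of > 9 mg/kg in this assay, at which 2 of the 3 values shown sit. Neither this step nor the one linking compound 1 with compound 3 can be read in size, so the three compounds give no ranking and no measure of what the benzylsulfanyl group contributes.

Going by these compounds, it remains open whether the sulfur or the benzyl group matters for compound 2 giving a number at this position, a question that methylsulfanyl, which keeps the sulfur and loses the benzyl, or benzyloxy, which keeps the benzyl and replaces the sulfur with oxygen, could address. Also open, on these data alone, is how far the true doses of compound 1 and compound 3 lie from the limit.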